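Swapping a chlorophenyl for a methylphenyl on a thioether arm

A few compounds are considered here, and "the series" means these few. Any claim that something is new, unique, unknown or untested is made for them only; others in the source may bear on it.

Measured compounds:
compound 1 `C#CCNC1CCc2c(SCCc3cccc(Br)c3)cccc21` — 620 nM
compound 2 `C#CCNC1CCc2c(SCc3cccc(Cl)c3)cccc21` — 1090 nM
compound 3 `C#CCNC1CCc2c(SCCc3ccc(Br)cc3)cccc21` — 1250 nM

All three were tested in an ADME assay on isolated protein for inhibition of Amine oxidase [flavin-containing] B (Homo sapiens); on this read-out lower numbers stand for stronger inhibition and higher numbers for weaker inhibition. Compound 2 sits second highest of the three numbers, yet its gaps to compound 3 and to compound 1 are both within the scatter, so nothing separates them. The new compound 4 `C#CCNC1CCc2c(SCc3ccc(C)cc3)cccc21` differs from compound 2 as follows: 4-methylphenyl in place of 3-chlorophenyl on a saturated chain carbon bound to a sulfur. Among the measured compounds shown here, the only measured step that resembles this is a 2.0-fold higher number from compound 1 to compound 3 (0.30 log units; within the scatter), which moved a bromine from one ring position to another and stayed within the scatter. For the measured compounds named here, no measured step exchanges a chlorine for a methyl group, so that part is unknown. Compound 4 is therefore expected to show a step of a 1.2-fold higher number from compound 2 to compound 4 (0.08 log units; within the scatter), meaning no change beyond the scatter. The estimate for compound 4 is 1300 nM, with a range from 450 nM to 3800 nM.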

Compound 4, half-maximal inhibitory concentration: 320 nM
Estimate against measurement, compound 4: 4.1-fold (0.61 log units) above, outside the stated range (below it).
By their numbers in this assay, from the lowest: compounds 4, 1, 2 and 3 (each within the scatter of the next, the first and the last beyond it).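

On a saturated chain carbon bound to a sulfur, 4-methylphenyl in place of 3-chlorophenyl gives a 3.4-fold lower number from compound 2 to compound 4 (0.53 log units; beyond the scatter) in this assay, so a ring change at this position can move the number beyond the scatter, which the earlier bromine step did not show. The swap alters both the ring substituent and its ring position at once, and the two effects cannot be separated here. Nothing measured here explains the lower number. On these data alone, how an unsubstituted phenyl, or a ring bearing an amine or a carboxylic acid, would behave at this position remains open.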